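This account rests on a few compounds, and the source may have more. Where it says the series, first, only, none or still open, it means among the compounds named here.

In an assay on HEK293 cells for inhibition of Voltage-dependent T-type calcium channel subunit alpha-1H (Homo sapiens), read by patch clamp, using a membrane potential dye (on this read-out higher numbers stand for weaker inhibition and lower numbers for stronger inhibition), three compounds have been measured so far:

Compound 1 `CC[C@H](C)[C@H](NC(=O)N1CCC2(CC1)C(=O)N(c1cccc(F)c1)C2c1ccc(Cl)cc1)C(=O)NC` gives 182 nM.
Compound 2 `COC(=O)[C@H](C)NC(=O)N1CCC2(CC1)C(=O)N(c1cccc(F)c1)C2c1ccc(Cl)cc1` gives 827 nM.
Compound 3 `C[C@H](NC(=O)N1CCC2(CC1)C(=O)N(c1cccc(F)c1)C2c1ccc(Cl)cc1)c1ccccc1` gives 139 nM.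

Compound 3 has the lowest of the three numbers. Its gap to compound 1 is within the scatter, as the step of a 1.3-fold lower number from compound 1 to compound 3 (0.12 log units; within the scatter) shows, so the two cannot be ranked against each other; only compound 2 stands clearly apart, as the step of a 5.9-fold lower number from compound 2 to compound 3 (0.77 log units; beyond the scatter) shows. Compound 4 `CC[C@H](NC(=O)N1CCC2(CC1)C(=O)N(c1cccc(F)c1)C2c1ccc(Cl)cc1)c1ccccc1` differs from compound 3 in one place: methyl in place of hydrogen on a saturated chain carbon, two bonds along the chain from an amide-type nitrogen and an aromatic carbon. Among the compounds with values here, none of the measured steps bears directly on this change: each of them swaps the whole group on the amide-type nitrogen, while here a single carbon is added and nothing else changes in what is counted. Within the data shown here, with no step of the same kind to lean on, the expectation is a step of a 1.0-fold higher number from compound 3 to compound 4 (0.00 log units; within the scatter), that is, nothing beyond the scatter. Compound 4 is therefore estimated at 140 nM, with a range from 60 nM to 350 nM.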

Compound 4, half-maximal inhibitory concentration: 224 nM
Compound 4: the middle estimate sits 1.6-fold (0.20 log units) below what was measured; low and high end bracket the measured number.
By their numbers in this assay, from the lowest: compounds 3, 1 and 4 (each within the scatter of the next); then compound 2.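

In this assay, the methyl that turns 1-phenylethyl into 1-phenylpropyl leaves the number within the scatter (a 1.6-fold higher number from compound 3 to compound 4 (0.21 log units; within the scatter)), so this saturated chain carbon accepts one more carbon with no change that can be distinguished from repeat-measurement noise. The 1-phenylpropyl group also cannot be ranked against the group in compound 1 (a 1.2-fold higher number from compound 1 to compound 4 (0.09 log units; within the scatter)), while the separation from compound 2 remains beyond the scatter (a 3.7-fold lower number from compound 2 to compound 4 (0.57 log units; beyond the scatter)), so this phenyl-bearing group, like the 1-phenylethyl group, stands clear of 1-(methoxycarbonyl)ethyl. No supporting evidence is available to explain these numbers.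

As far as these compounds go, one added carbon is a small probe, so it remains open whether a longer chain, such as propyl or butyl, would also stay within the scatter. From the compounds shown here alone, it is equally open whether an amine or a hydroxyl on the ethyl chain would do so.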